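The source may report more compounds than this note shows. Statements on the series, on what has been measured and on what is new or still open speak of the compounds shown alone.

In a functional assay on MOLT-4 cells (Homo sapiens) for antiproliferative activity (on this read-out higher numbers stand for weaker inhibition and lower numbers for stronger inhibition), three compounds built on a shared core have been measured. Compound 1 (`COc1cc(C(=O)c2sc(-c3cccc([N+](=O)[O-])c3)cc2N)cc(OC)c1OC`) gives 7.5 nM, compound 2 (`COc1cc(C(=O)c2sc(-c3ccccc3)cc2N)cc(OC)c1OC`) gives 5.3 nM, and compound 3 (`COc1cc(C(=O)c2sc(-c3ccncc3)cc2N)cc(OC)c1OC`) gives 88 nM, the highest number of the three. Compound 4 (`COc1cccc(-c2cc(N)c(C(=O)c3cc(OC)c(OC)c(OC)c3)s2)c1`) differs from compound 3 by one group: 3-methoxyphenyl in place of pyridin-4-yl on an aromatic carbon. Two large steps bear on this, a 17-fold higher number from compound 2 to compound 3 (1.22 log units; beyond the scatter) and a 12-fold higher number from compound 1 to compound 3 (1.07 log units; beyond the scatter), each ending at the pyridin-4-yl group. For the measured compounds named here, a third step, a 1.4-fold lower number from compound 1 to compound 2 (0.15 log units; within the scatter), suggests that a substituent on the carbon-only ring may matter little, although no measured compound carries methoxy. A large drop is therefore expected, and the expected step is an 8.8-fold lower number from compound 3 to compound 4 (0.94 log units; beyond the scatter). The estimate for compound 4 is 10 nM, within an expected range of 3 nM to 35 nM.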

Compound 4, half-maximal inhibitory concentration: 17 nM
The estimate for compound 4 lay 1.7-fold (0.23 log units) below the measured number; low and high end bracket the measured number.
By their numbers in this assay, from the lowest: compounds 2 and 1 (each within the scatter of the next); then compound 4; then compound 3.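

In this assay, a 5.2-fold lower number from compound 3 to compound 4 (0.71 log units; beyond the scatter) shows that a carbon-only ring bearing methoxy also gives stronger inhibition than pyridin-4-yl at this position. Methoxy does have a cost, though: a 3.2-fold higher number from compound 2 to compound 4 (0.51 log units; beyond the scatter) and a 2.3-fold higher number from compound 1 to compound 4 (0.36 log units; beyond the scatter) both lie beyond the scatter, so a substituent on the carbon-only ring can matter, if only modestly.

No available measurement gives a reason for these differences. Going by these compounds, it also remains open how a hydroxyl group or an amine on that ring would compare.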